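A Flat Series Meets a Diethylamino Group

A few compounds are considered here, and "the series" means these few. Any claim that something is new, unique, unknown or untested is made for them only; others in the source may bear on it.

In a functional assay on A549 cells (Homo sapiens) for cytotoxicity, read by MTT assay, with a stated time of 72 h (on this read-out lower numbers stand for stronger inhibition and higher numbers for weaker inhibition), compound 1 `COc1cc2ncnc(Nc3ccc(F)c(Cl)c3)c2cc1NC(=O)N/N=C/c1ccc(C#N)cc1` gives 32200 nM, compound 2 `COc1cc2ncnc(Nc3ccc(F)c(Cl)c3)c2cc1NC(=O)N/N=C/c1ccc(F)cc1Cl` gives 28200 nM, and compound 3 `COc1cc2ncnc(Nc3ccc(F)c(Cl)c3)c2cc1NC(=O)N/N=C/c1ccc(O)cc1O` gives 31400 nM, so compound 3 cannot be separated from the other two. The unmeasured compound 4 `CCN(CC)c1ccc(/C=N/NC(=O)Nc2cc3c(Nc4ccc(F)c(Cl)c4)ncnc3cc2OC)c(O)c1` differs from it by diethylamino in place of hydroxy on an aromatic carbon, turning 2,4-dihydroxyphenyl into 4-(diethylamino)-2-hydroxyphenyl. The nearest evidence is the three exchanges of the substituted phenyl group: a 1.1-fold lower number from compound 1 to compound 2 (0.06 log units; within the scatter), a 1.0-fold lower number from compound 1 to compound 3 (0.01 log units; within the scatter) and a 1.1-fold higher number from compound 2 to compound 3 (0.05 log units; within the scatter), all within the scatter. None of them tests diethylamino itself, so no step beyond the scatter is expected in this assay. The change is estimated as a 1.3-fold lower number from compound 3 to compound 4 (0.12 log units; within the scatter). Compound 4 is expected at 24000 nM, with an estimated range of 9000 nM to 45000 nM.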

Compound 4, half-maximal inhibitory concentration: 27300 nM
For compound 4 the middle estimate is 1.1-fold (0.06 log units) below the measured one; measured number inside the range.
By their numbers in this assay, from the lowest: compounds 4, 2, 3 and 1 (each within the scatter of the next).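

Diethylamino brings five heavy atoms where hydroxy had one and removes a hydrogen-bond donor, yet in this assay this aromatic carbon tolerates the change with no step beyond the scatter (a 1.2-fold lower number from compound 3 to compound 4 (0.06 log units; within the scatter)). The exchanges of the whole substituted phenyl group for 4-(diethylamino)-2-hydroxyphenyl stay equally flat (a 1.0-fold lower number from compound 2 to compound 4 (0.01 log units; within the scatter); a 1.2-fold lower number from compound 1 to compound 4 (0.07 log units; within the scatter)). No measurement here offers an explanation for this flatness.

On these data alone, whether any group at this carbon can move the number remains open. A carboxylic acid or a morpholine ring in place of diethylamino would test this further.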